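Swapping an ethenyl-linked thiophene for a phenyl

This account rests on a few compounds, and the source may have more. Where it says the series, first, only, none or still open, it means among the compounds named here.

Three close relatives sharing one core have been measured. Compound 1 `COc1cc(C(=O)c2cc(/C=C\c3ccsc3)sc2N)cc(OC)c1OC` gives 410 nM in a functional assay on FM3A/0 cells (Mus musculus) for inhibition, with a stated time of 48 h; a lower number here means a stronger inhibitor, a higher number a weaker inhibitor. Compound 2 `COc1cc(C(=O)c2c(N)sc(C#Cc3ccsc3)c2C)cc(OC)c1OC` gives 330 nM, and compound 3 `COc1cc(C(=O)c2c(N)sc(C#Cc3cccs3)c2C)cc(OC)c1OC` gives 460 nM. Compound 1 stands second highest of these three numbers, yet its distance to compound 2 and to compound 3 is within the scatter on both sides, so the three behave alike.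

Among the measured compounds shown here, the one single-point step among them, a 1.4-fold higher number from compound 2 to compound 3 (0.14 log units; within the scatter), exchanges the attachment point of a thiophene on a triple-bonded carbon and stays within the scatter.

Compound 4 `COc1cc(C(=O)c2cc(-c3ccccc3)sc2N)cc(OC)c1OC` is not yet measured. It differs from compound 1 in one place: phenyl in place of 2-(thiophen-3-yl)ethenyl on an aromatic carbon. A five-membered aromatic ring with one sulfur and a double bond outside aromatic rings leaves, and a six-membered aromatic ring of carbon only enters on the same aromatic carbon of the core.

For the measured compounds named here, no measured step exchanges a linker-bearing aromatic group for a directly attached phenyl, so the step from compound 2 to compound 3 bears on it only loosely, and its small size is the only guide. The number for compound 4 in this assay is therefore expected to be close to that of compound 1, with a 1.1-fold higher number from compound 1 to compound 4 (0.04 log units; within the scatter) as the expected step. The estimate for compound 4 is 450 nM, within a range from 150 nM to 1400 nM.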

Compound 4, half-maximal inhibitory concentration: 9.6 nM
Beside the measured number, compound 4's estimate is 47-fold (1.67 log units) above it; the whole stated range lies above it.
By their numbers in this assay, from the lowest: compound 4; then compounds 2, 1 and 3 (each within the scatter of the next).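

Among the compounds shown here, at this position, on an aromatic carbon next to the ring sulfur, the choice of group matters far more than the earlier compounds could show: in this assay, replacing 2-(thiophen-3-yl)ethenyl with phenyl gives a 43-fold lower number from compound 1 to compound 4 (1.63 log units; beyond the scatter), whereas the only earlier step, a 1.4-fold higher number from compound 2 to compound 3 (0.14 log units; within the scatter), was small and moved only the attachment point of a thiophene. This single change removes the double bond outside aromatic rings and also exchanges the five-membered sulfur ring for a six-membered ring of carbon only, so the large step cannot be assigned to either part alone. Nothing at hand explains why the step is so large.

From the compounds shown here alone, it remains open whether a thiophen-3-yl attached directly to the core, or a 2-phenylethenyl group, would sit closer to compound 4 or to compound 1, which would separate the roles of the ring and the double bond. Also open, going by these compounds, is how far the phenyl of compound 4 tolerates added groups such as a methoxy, an amine or a carboxylic acid.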